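From Chloro to Bromo: Cytotoxicity Before the Measurement

The source may hold more compounds than are shown below. What is called first, only, known or untested is meant among the compounds shown, and "the series" means these compounds.

Measured so far:
Compound 1, `O=C(N/N=C/c1ccccc1)c1cccnc1`: in an ADME assay on Vero cells (Chlorocebus sabaeus) for cytotoxicity, read by microscopy (on this read-out higher numbers stand for lower toxicity in this test and lower numbers for higher toxicity in this test), compound 1 gives > 100 ug/mL, which is a limit of the test rather than a number.
Compound 2, `O=C(N/N=C/c1ccc(Cl)cc1)c1cccnc1`: in this assay compound 2 gives > 100 ug/mL, again a limit rather than a number.

Compound 2 therefore stands at the upper edge of what this test can report, and the step that the two limits leave unreadable from compound 1 to compound 2 cannot be read in size because both values are limits. The next compound, compound 3, `O=C(N/N=C/c1ccc(Br)cc1)c1cccnc1`, differs from compound 2 by bromo in place of chloro on an aromatic carbon. Going by the values given here, the only measured step, from compound 1 to compound 2, offers no readable size, so it gives no direction to expect for this assay. What the numbers do show is the ceiling described by the limit of > 100 ug/mL in this assay, at which 2 of the 2 values shown sit. Compound 3 is expected to sit at that ceiling again, with an estimated step that the limit leaves unreadable from compound 2 to compound 3. The estimate for compound 3 is 150 ug/mL, between 70 ug/mL and 400 ug/mL.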

Compound 3, minimum cytotoxic concentration: > 100 ug/mL
Compound 3: only a limit was reported; the forecaster's own chance of this, stated with the estimate: 85%; the middle value is on the limit's open side.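

In this assay compound 3 gives > 100 ug/mL, which is a limit and not a number, so no step among compound 1, compound 2 and compound 3 can be read: the limit of > 100 ug/mL in this assay, at which 3 of the 3 values shown sit.

The compounds shown leave open at what concentration each becomes toxic to the cells, and whether chloro or bromo in place of hydrogen makes any difference.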